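The source may hold more compounds than are shown below. What is called first, only, known or untested is meant among the compounds shown, and "the series" means these compounds.

Compound 3 `O=C(O)C1=Cc2ccccc2OC1(OCc1cc(-c2ccc(F)cc2F)no1)C(F)(F)F` stands at the edge of what a functional assay on A549 cells (Homo sapiens) for inhibition, read by MTT assay, with a stated time of 24 h (a lower number here means a stronger inhibitor, a higher number a weaker inhibitor), can report: its value of > 150000 nM is a limit, not a number. Compound 2 `O=C(O)C1=Cc2ccccc2OC1(OCc1cc(-c2ccc3ccccc3c2)no1)C(F)(F)F` likewise returns only a limit, > 150000 nM, in this assay. Compound 1 `Cc1ccc(-c2cc(COC3(C(F)(F)F)Oc4ccccc4C=C3C(=O)O)on2)cc1` gives 51200 nM in this assay. Both aryl replacements raise the number: an at least 2.9-fold higher number from compound 1 to compound 2 (0.46 log units; beyond the scatter), and an at least 2.9-fold higher number from compound 1 to compound 3 (0.46 log units; beyond the scatter), each reaching (the limit of > 150000 nM in this assay, at which 2 of the 3 values shown sit). The comparison a step that the two limits leave unreadable from compound 2 to compound 3 gives no readable size. Compound 4 `O=C(O)C1=Cc2ccccc2OC1(OCc1cc(-c2ccc(F)cc2)no1)C(F)(F)F` carries the change (hydrogen in place of fluoro on an aromatic carbon), which brings its aryl group nearer to that of compound 1. Compound 4 is therefore expected to give about 120000 nM, between 40000 nM and 300000 nM, in this assay. The expected step is an at least 1.2-fold lower number from compound 3 to compound 4 (0.09 log units; that floor lies within the scatter).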

Compound 4, half-maximal inhibitory concentration: > 150000 nM
Compound 4: a limit, no number (the forecaster's own chance of this, stated with the estimate: 50%); at least 1.2-fold (0.09 log units) between middle value and limit.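

In this assay compound 4 returns only a limit, > 150000 nM. Losing one fluoro from the 2,4-difluorophenyl group does not bring back a readable number, so a single fluoro in place of the methyl of compound 1 is already enough for an at least 2.9-fold higher number from compound 1 to compound 4 (0.46 log units; beyond the scatter), while the steps among compound 2, compound 3 and compound 4 cannot be read. Among the aryl groups shown, only the 4-methylphenyl of compound 1 gives a number, and the limit now holds most of the set: the limit of > 150000 nM in this assay, at which 3 of the 4 values shown sit.

Going by these compounds, whether an ethyl group or an amine in place of that methyl would give a readable number stays open. So does any order among compound 2, compound 3 and compound 4.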